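A few compounds are considered here, and "the series" means these few. Any claim that something is new, unique, unknown or untested is made for them only; others in the source may bear on it.

Measured so far:
Compound 1, `C=CC[N+](C)(C)c1ccccc1OC`, gives 2890 nM in a functional assay with Cavia porcellus as the target; a higher number here means a weaker inhibitor, a lower number a stronger inhibitor.
Compound 2, `C[N+](C)(Cc1ccccc1)c1ccccc1O`, gives > 3000 nM in this assay.

For compound 2 the result in this assay is a limit of the assay and not a number; it sits at the limit of > 3000 nM in this assay, at which 1 of the 2 values shown sits. So compound 2 stands at the weak end of what has been measured, with nothing closer known about it.

Compound 3, `COc1ccccc1[N+](C)(C)Cc1ccccc1`, differs from compound 2 by methyl in place of hydrogen on an oxygen on an aromatic ring. Among the measured compounds shown here, no step between measured compounds covers this exchange. The step from compound 2 to compound 3 is expected to be a step that the limit leaves unreadable from compound 2 to compound 3, which is no more than the usual scatter, and its direction cannot be fixed while compound 2 is known only as a limit. Compound 3 is expected to stay weak because compound 1 with the same methoxy group gives 2890 nM. For compound 3 the estimate in this assay is 3500 nM, within a range from 1500 nM to 9000 nM.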

Compound 3, half-maximal inhibitory concentration: > 3000 nM
Compound 3: no number, only a limit; the forecaster's own chance of this, stated with the estimate: 50%; the middle value does not contradict the limit.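

Exchanging hydroxy for methoxy leaves the compound at the same limit of the assay, so the step between these two compounds cannot be read in either direction: the limit of > 3000 nM in this assay, at which 2 of the 3 values shown sit.

With phenyl in place of vinyl on the saturated chain carbon, the comparison gives an at least 1.0-fold higher number from compound 1 to compound 3 (0.01 log units; that floor lies within the scatter). On these data alone, this exchange therefore brings no readable gain in strength in this assay, and the true size of the step stays unknown.

As far as these compounds go, neither compound 2 nor compound 3 has an actual number, so what the change from hydroxy to methoxy does to strength remains open. Also open, from the compounds shown here alone, is whether another group on that oxygen, such as ethyl or a longer chain, or an amine on the saturated chain carbon, would bring a measurable value inside the range of the assay.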